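Benzyl to (ethoxycarbonyl)methyl: notes on compound 4

A few compounds are considered here, and "the series" means these few. Any claim that something is new, unique, unknown or untested is made for them only; others in the source may bear on it.

Values in a functional assay on B16 cells (Mus musculus) for cytotoxicity, read by MTT assay, with a stated time of 48 h; a lower number here means a stronger inhibitor, a higher number a weaker inhibitor:
- compound 1 `C#CC(=O)Nc1ccc(C#C)cc1`: 6300 nM
- compound 2 `CC(=O)OCCn1cc(CNC(=O)c2cn(CCOC(C)=O)nn2)nn1`: > 100000 nM (a limit of the assay)
- compound 3 `O=C(Nc1cccc(-c2cn(Cc3ccccc3)nn2)c1)c1cn(Cc2ccccc2)nn1`: 4500 nM

Compound 3 gives 4500 nM, within the scatter of compound 1 at 6300 nM. The only other entry is the limit for compound 2.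

Compound 4 `CCOC(=O)Cn1cc(-c2cccc(NC(=O)c3cn(Cc4ccccc4)nn3)c2)nn1` carries ethoxycarbonyl in place of phenyl on a saturated chain carbon bound to an aromatic nitrogen. Within the data shown here, no measured pair in this assay isolates this change. Compound 2, which also holds ester groups, reads > 100000 nM, and this is a limit. A moderate step beyond the scatter towards a weaker inhibitor is therefore expected, namely a 3.3-fold higher number from compound 3 to compound 4 (0.52 log units; beyond the scatter). The estimated value for compound 4 is 15000 nM, with an expected range of 5000 nM to 60000 nM.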

Compound 4, half-maximal inhibitory concentration: 21000 nM
Beside the measured number, compound 4's estimate is 1.4-fold (0.15 log units) below it; the range from low to high includes it.
By their numbers in this assay, from the lowest: compounds 3 and 1 (each within the scatter of the next); then compound 4. At a limit, above all of these: compound 2.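

Ethoxycarbonyl in place of phenyl on a saturated chain carbon bound to an aromatic nitrogen gives the first single-place step of the series in this assay (a 4.7-fold higher number from compound 3 to compound 4 (0.67 log units; beyond the scatter)). The position therefore responds to this change, yet compound 4 still reads as a number without its phenyl ring. Compound 2, which also holds ester groups, differs in more than one place, and its reading is a limit: the limit of > 100000 nM in this assay, at which 1 of the 4 values shown sits.

As far as these compounds go, whether the step follows the loss of phenyl or the arrival of the ester stays open. A carboxylic acid or a plain ethyl group at this place would separate the two.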